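Cytotoxicity Limits and an Ethoxy Replacement

The source may report more compounds than this note shows. Statements on the series, on what has been measured and on what is new or still open speak of the compounds shown alone.

Compound 1, `CCOC(=O)CCCCCOc1cccc(CN(C(=O)c2ccc(-c3cccc(-c4ccccc4)c3)cc2)C(C)C)c1`: > 26000 nM
Compound 2, `CCOC(=O)CCCCCOc1cccc(CN(C(=O)c2ccc(-c3cccc(Oc4ccccc4)c3)cc2)C(C)C)c1`: > 19600 nM
Compound 3, `CCOC(=O)CCCCCOc1cccc(CN(C(=O)c2ccc(-c3cccc(-c4nnc(C)o4)c3)cc2)C(C)C)c1`: > 26000 nM

All three compounds were tested in an ADME assay on HEK293 cells (Homo sapiens) for cytotoxicity, read by CellTiter-Glo and resazurin assay, with a stated time of 72 h; a higher number here means that more compound is needed for the effect, a lower number that less compound is needed. None gave a number: the value of compound 1 is a limit of the assay. The value of compound 2 is likewise a limit. The value of compound 3 is a limit as well. These limits are the limit of > 26000 nM in this assay, at which 2 of the 3 values shown sit, and (the limit of > 19600 nM in this assay, at which 1 of the 3 values shown sits). Within the data shown here, compound 3 therefore stands at a limit, and the two other values shown are limits too, so no compound can be set above or below another.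

The change to compound 4, `CCOC(=O)CCCCCOc1cccc(CN(C(=O)c2ccc(-c3cccc(OCC)c3)cc2)C(C)C)c1`, is ethoxy in place of 5-methyl-1,3,4-oxadiazol-2-yl on an aromatic carbon. The measured steps that bear on it, a step that the two limits leave unreadable from compound 1 to compound 2, a step that the two limits leave unreadable from compound 1 to compound 3 and a step that the two limits leave unreadable from compound 2 to compound 3, all run between limits and cannot be read in size or direction. They only show that exchanging the group at this position has not produced a cytotoxicity readable within the range of this assay.

The step from compound 3 to compound 4 is therefore expected to be a step that the limit leaves unreadable from compound 3 to compound 4. Compound 4 is estimated at 30000 nM, between 15000 nM and 60000 nM, most likely reported again only as a limit.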

Compound 4, half-maximal effective concentration: > 22300 nM
Compound 4: only a limit was reported; the forecaster's own chance of this, stated with the estimate: 85%; the middle value lies beyond the limit too.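

In this assay compound 4 gives > 22300 nM as a limit and not a number. Its steps from compound 1, compound 2 and compound 3 all run between limits and cannot be read in size or direction. The compounds shown leave open at what concentration any of them would harm these cells, and whether the group exchanged here affects that concentration.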